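Saturated core analogues of the aza-pyrimidinone series

The source may hold more compounds than are shown below. What is called first, only, known or untested is meant among the compounds shown, and "the series" means these compounds.

Compound 1 `Nc1ncn(CCC2(N)OC(=O)C(OCc3ccccc3)=C2OCc2ccccc2)c(=O)n1` carries the saturated core with a free amine. In a functional assay on SW-620 cells (Homo sapiens) for inhibition, read by MTT assay, with a stated time of 72 h (on this read-out lower numbers stand for stronger inhibition and higher numbers for weaker inhibition), compound 1 returns > 100000 nM, which is a limit of the assay and not a number. Compound 2 `Nc1ncn(C/C=C2\OC(=O)C(OCc3ccccc3)=C2OCc2ccccc2)c(=O)n1` has the exocyclic double bond instead and gives 5620 nM. Compound 3 `O=C1O/C(=C\Cn2ccc(NC(=O)c3ccccc3)nc2=O)C(OCc2ccccc2)=C1OCc1ccccc1` returns > 100000 nM, again a limit of the assay. Two of three results thus sit at the limit of > 100000 nM in this assay, at which 2 of the 3 values shown sit. Compound 4 `NC1(CCn2ncc(=O)[nH]c2=O)OC(=O)C(OCc2ccccc2)=C1OCc1ccccc1` differs from compound 1 by a group of 8 heavy atoms (3 carbon, 3 nitrogen, 2 oxygen; one six-membered aromatic ring with 3 hetero atoms) in place of a group of 8 heavy atoms (3 carbon, 4 nitrogen, 1 oxygen; one six-membered aromatic ring with 3 hetero atoms), on a saturated chain carbon, two bonds along the chain from a saturated ring carbon; the saturated core of compound 1 is kept. Within the data shown here, no measured pair shows a change of this kind, so no step beyond the scatter is expected, and the step from compound 1 to compound 4 is estimated at a number no higher from compound 1 to compound 4 (the limit leaves the size open) because compound 1 already sits at the limit of > 100000 nM in this assay, at which 2 of the 3 values shown sit. For compound 4 the expected value is 100000 nM, with a range from 30000 nM to 300000 nM.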

Compound 4, half-maximal inhibitory concentration: > 100000 nM
Compound 4: only a limit was reported (the forecaster's own chance of this, stated with the estimate: 70%); the middle value sits exactly at the limit.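

Compound 1 and compound 4 both give only a limit of the assay and not a number, so no step can be read between them: the limit of > 100000 nM in this assay, at which 3 of the 4 values shown sit.

The compounds shown leave open whether exchanging this group on the core of compound 1 changes inhibition at all.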